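The source may report more compounds than this note shows. Statements on the series, on what has been measured and on what is new or still open speak of the compounds shown alone.

Measured in an in vitro ADME assay on microsomes from liver (Homo sapiens) for metabolic stability, tested at 0.2 uM; on this read-out lower numbers stand for slow clearance and higher numbers for fast clearance:
- compound 1 `Cc1c(COc2cccc(OCC3CCOCC3)c2)[nH]c2ccccc2c1=O`: 214 mL/min/kg
- compound 2 `Cc1c(COc2cccc(OCC3CCOCC3)c2)[nH]c2ccc(Cl)cc2c1=O`: > 1000 mL/min/kg, a limit of the assay
- compound 3 `Cc1c(COc2cccc(OCC3CCOCC3)c2)[nH]c2ccc(C(=O)O)cc2c1=O`: < 20 mL/min/kg, a limit of the assay

Compound 3 stands lowest of the three, with steps beyond the scatter to both others, though its value is a limit and not an exact number. Compound 4 `Cc1c(COc2cccc(OCC3CCOCC3)c2)[nH]c2ccc(-c3cccnc3)cc2c1=O` puts pyridin-3-yl in place of the carboxy on an aromatic carbon: pyridin-3-yl in place of carboxy on an aromatic carbon.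

Going by the values given here, two measured steps bear on this change, and both are large: an at least 10-fold lower number from compound 1 to compound 3 (1.02 log units; beyond the scatter) and an at least 50-fold lower number from compound 2 to compound 3 (1.69 log units; beyond the scatter). A third, an at least 4.6-fold higher number from compound 1 to compound 2 (0.66 log units; beyond the scatter), shows that a group other than carboxy can push the number up rather than down. Compound 4 has no carboxy, and compound 1, which also lacks it, gives 214 mL/min/kg in this assay. Among the compounds with values here, no measured compound carries pyridin-3-yl, so the range must stay wide.

A large upward step is therefore expected, estimated as an at least 15-fold higher number from compound 3 to compound 4 (1.17 log units; beyond the scatter). The estimate for compound 4 is 300 mL/min/kg, with an expected range of 80 mL/min/kg to 1000 mL/min/kg.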

Compound 4, clearance: 756 mL/min/kg
Beside the measured number, compound 4's estimate is 2.5-fold (0.40 log units) below it, within the range that was stated.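

In this assay, starting from the limit of the assay held by compound 3, pyridin-3-yl brings an at least 37-fold higher number from compound 3 to compound 4 (1.57 log units; beyond the scatter), so the low number does not carry over to this ring in place of carboxy. Pyridin-3-yl also gives a 3.5-fold higher number from compound 1 to compound 4 (0.55 log units; beyond the scatter), which means that chloro and pyridin-3-yl both stand above plain hydrogen at this position, and only carboxy, in compound 3, goes against that pattern. The remaining step, an at least 1.3-fold lower number from compound 2 to compound 4 (0.12 log units; that floor lies within the scatter), starts from the limit of the assay held by compound 2 and its floor lies within the scatter, so compound 2 and compound 4 cannot be ranked.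

The compounds shown leave open whether a primary amide or a methyl ester at this position would stay low like compound 3 or rise like compound 4. They also leave open whether carboxy would give the same low number on another carbon of this ring.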